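The source may report more compounds than this note shows. Statements on the series, on what has been measured and on what is new or still open speak of the compounds shown alone.

Measured so far:
compound 1 `C[C@@H](Nc1nccc(Cl)c1NC(=O)CC#N)c1ccc(-c2cccc(F)c2C#N)cc1` — in an in vivo ADME assay on the whole organism for pharmacokinetics, with Canis familiaris (Canis lupus familiaris) as the target, at a dose of 1 mg/kg by the intravenous route (on this read-out lower numbers stand for slow clearance and higher numbers for fast clearance), compound 1 gives "not determined" (no result reported)
compound 2 `C[C@@H](Nc1nccc(Cl)c1NC(=O)CC#N)c1ccc(-c2cccc(F)c2-c2nnn(C)n2)cc1` — 2.4 mL/min/kg

For the measured compounds named here, compound 2 holds the only number in this assay; compound 1 carries no result there, so no step between measured compounds can be drawn. Compound 3 `Cc1nc(-c2c(F)cccc2-c2ccc([C@@H](C)Nc3nccc(Cl)c3NC(=O)CC#N)cc2)no1` differs from compound 2 by 5-methyl-1,2,4-oxadiazol-3-yl in place of 2-methyl-2H-tetrazol-5-yl on an aromatic carbon. Going by the values given here, with no measured step to rest on, the expectation is a shift no larger than the scatter, a 1.1-fold higher number from compound 2 to compound 3 (0.03 log units; within the scatter), in either direction. Compound 3 is estimated at 2.6 mL/min/kg, within 1.2 mL/min/kg to 5.5 mL/min/kg.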

Compound 3, clearance: 5.9 mL/min/kg
Compound 3: middle estimate off by 2.3-fold (0.36 log units), on the low side; measured number outside the range, above it.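

In this assay, the aromatic carbon ortho to a fluoro group proves sensitive to which five-membered aromatic ring it carries: 5-methyl-1,2,4-oxadiazol-3-yl in place of 2-methyl-2H-tetrazol-5-yl gives a 2.5-fold higher number from compound 2 to compound 3 (0.39 log units; beyond the scatter). For the compounds shown here, this is the first readable step, and although modest, it shows that the two rings are not interchangeable on this read-out. Nothing available explains the shift.

Steps involving compound 1 cannot be read. One step also leaves open how clearance would respond to a carboxylic acid or a primary amine at this position.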